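From 4-chlorophenyl to 4-methoxyphenyl without a measured anchor

The source may report more compounds than this note shows. Statements on the series, on what has been measured and on what is new or still open speak of the compounds shown alone.

Two compounds with a shared core frame this account. In an ADME assay on HMEC-1 cells (Homo sapiens) for antiproliferative activity (on this read-out higher numbers stand for weaker inhibition and lower numbers for stronger inhibition), compound 1 (`COc1ccc(-c2snnc2-c2cc(OC)c(OC)c(OC)c2)cc1O`) gives 3.9 nM, a potent result on this read-out. Compound 2 (`COc1cc(-c2nnsc2-c2ccc(Cl)cc2)cc(OC)c1OC`) offers no such reference point: its entry reads "not determined" (no result reported), so it has no number from which to measure a change.

The next compound, compound 3 (`COc1ccc(-c2snnc2-c2cc(OC)c(OC)c(OC)c2)cc1`), differs from compound 2 by methoxy in place of chloro on an aromatic carbon, para to a large group, taking 4-chlorophenyl to 4-methoxyphenyl: methoxy in place of chloro on an aromatic carbon.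

Among the measured compounds shown here, no measured step shows what this change does in this assay, and the size of the change from compound 2 cannot be read from the data. For the measured compounds named here, the only available number is that of compound 1 at 3.9 nM. Compound 3 is therefore expected to stay potent but to fall on the weaker side of that value, a moderate step beyond the scatter toward higher numbers. For compound 3 the estimated value is 30 nM, with an expected range of 4 nM to 300 nM.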

Compound 3, half-maximal inhibitory concentration: 24.6 nM
Beside the measured number, compound 3's estimate is 1.2-fold (0.09 log units) above it, and the stated range covers the measured number.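

With the hydroxy group of compound 1 replaced by hydrogen, this assay gives its first readable step among these compounds, a 6.3-fold higher number from compound 1 to compound 3 (0.80 log units; beyond the scatter), so this hydroxy group makes a difference that lies beyond the usual scatter. The step is modest, and compound 3 still gives 24.6 nM, which shows that potency on this read-out does not depend entirely on the hydroxy group, with the methoxy on the same aromatic ring left in place. The step from compound 2 to compound 3 cannot be read, as compound 2 has no number, so the effect of methoxy in place of chloro stays unknown, and nothing at hand gives a cause for the measured step.

The compounds shown leave open whether an amine or a fluorine atom in the place of the hydroxy group would stay closer to compound 1 or to compound 3. They also leave open how a longer chain such as ethoxy in the place of the methoxy on that ring would read in this assay.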